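Sulfonamide series: aryl swap on the sulfonyl group

The source may report more compounds than this note shows. Statements on the series, on what has been measured and on what is new or still open speak of the compounds shown alone.

Measured compounds:
compound 1 `COc1ccc(S(=O)(=O)N(C)CCOCC(=O)N(C)Cc2ccc(C3=NCCN3)cc2)c(C)c1`: 8.6
compound 2 `COc1cc(C)c(S(=O)(=O)N(C)CCOCC(=O)N2CCC(N3CCN(C(C)C)CC3)CC2)c(C)c1`: 8.5

In a functional assay on Umbilical vein for antagonist activity at B1 bradykinin receptor (Homo sapiens), using Schild analysis, with a stated time of 30 min (on this read-out lower numbers stand for lower potency and higher numbers for higher potency (the scale is a negative logarithm)), compound 1 gives 8.6. In this assay compound 2 gives 8.5. Of the two numbers that of compound 1 is the higher, but the gap to compound 2 lies within the usual scatter, so the two read as equivalent.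

Compound 3 `Cc1c(Cl)cccc1S(=O)(=O)N(C)CCOCC(=O)N(C)Cc1ccc(C2=NCCN2)cc1` has not been measured. It differs from compound 1 in one place: 3-chloro-2-methylphenyl in place of 4-methoxy-2-methylphenyl on a sulfonyl sulfur. Among the measured compounds shown here, no pair of measured compounds shows this kind of swap, so the size of the step rests on the change itself. Loss of the single hydrogen-bond acceptor and entry of chlorine is a modest alteration at the aryl sulfonyl end; the expected step from compound 1 to compound 3 is a number 0.20 log units lower from compound 1 to compound 3 (within the scatter), that is, nothing clearly beyond the scatter, with a slight lean downward. Compound 3 is therefore estimated at 8.4 in this assay, with a range from 7.7 to 9.1.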

Compound 3, negative logarithm of the antagonist equilibrium constant: 8
Beside the measured number, compound 3's estimate is 0.40 log units above it; measured number inside the range.
By their numbers in this assay, from the lowest: compound 3; then compounds 2 and 1 (each within the scatter of the next).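

In this assay the swap to 3-chloro-2-methylphenyl on a sulfonyl sulfur gives a number 0.60 log units lower from compound 1 to compound 3 (beyond the scatter) and so shows that the aryl group at this position can shift potency by more than the usual scatter. Compound 1 and compound 2 differ in more than one place, so their pairing could not show this. The swap removes a methoxy group and brings in chlorine in a single step, and no measurement shown here accounts for the fall.

From the compounds shown here alone, whether the fall follows the loss of the methoxy group or the entry of chlorine stays open. Also open, going by these compounds, is how a plain phenyl or a pyridyl on the sulfonyl sulfur would compare with the two aryl groups in compound 1 and compound 3.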